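A few compounds are considered here, and "the series" means these few. Any claim that something is new, unique, unknown or untested is made for them only; others in the source may bear on it.

Measured in a functional assay on HL-60 cells (Homo sapiens) for inhibition, read by MTT assay, with a stated time of 72 h; on this read-out higher numbers stand for weaker inhibition and lower numbers for stronger inhibition:
Compound 1 `Cc1ccc(N2CCN(C(=O)c3oc(C)nc3-c3ccccc3)CC2)cc1` gives > 1000 nM in this assay, a limit and not a number.
Compound 2 `Cc1nc(-c2ccccc2)c(C(=O)N2CCN(c3ccc(C(=O)C(C)C)cc3)CC2)o1` is reported in this assay as "not active" (no number reported).
Compound 3 `CCc1nc(-c2ccc(F)cc2)c(C(=O)N2CCN(c3cccc(OC)c3)CC2)o1` gives 411 nM in this assay.

Compound 1 therefore stands at the floor of what this assay resolves: its entry is the limit of > 1000 nM in this assay, at which 1 of the 3 values shown sits, and nothing more is known of it than that. Compound 2 also has no number. For the measured compounds named here, compound 3 is the only member of the set with a measured half-maximal inhibitory concentration, and it differs from compound 1 in several places at once, so no single step between measured compounds can be read from these three entries.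

The next compound, compound 4 `Cc1nc(-c2ccccc2)c(C(=O)N2CCN(c3ccccc3F)CC2)o1`, changes compound 1 in one place: 2-fluorophenyl in place of 4-methylphenyl on an amine nitrogen in a ring. Going by the values given here, with no measured step to lean on, the expectation for this change is a shift of at most modest size, not confidently beyond the usual scatter, and the step that the limit leaves unreadable from compound 1 to compound 4 is estimated on that basis. Compound 4 is accordingly expected to sit near 1500 nM, with a plausible range from 400 nM to 6000 nM, and a fair chance that this assay again reports only a limit for compound 4.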

Compound 4, half-maximal inhibitory concentration: 147 nM
Compound 4: the middle estimate sits 10-fold (1.01 log units) above what was measured; measured number outside the range, below it.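

In this assay, for the compounds shown here, 2-fluorophenyl in place of 4-methylphenyl on an amine nitrogen in a ring gives the only readable step so far, an at least 6.8-fold lower number from compound 1 to compound 4 (0.83 log units; beyond the scatter), which shows that a change confined to this aryl group can move the read-out beyond the scatter. The two groups match in heavy-atom count, in their single six-membered aromatic ring of carbon only and in carrying no hydrogen-bond donors or acceptors, so the step arises without a change in any of these counts. The step is a bound and its full size stays unknown, because compound 1 carries a limit and not a number: the limit of > 1000 nM in this assay, at which 1 of the 4 values shown sits.

The compounds shown do not separate the arrival of the fluorine from the loss of the methyl group, and they leave open what a plain phenyl, a 2-chlorophenyl or a 2-methoxyphenyl would give on the same nitrogen. Steps involving compound 2 or compound 3 cannot be read, since compound 2 has no number and compound 3 differs from the others in several places at once.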